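This account rests on a few compounds, and the source may have more. Where it says the series, first, only, none or still open, it means among the compounds named here.

Measured so far in an assay on cells for displacement of a labelled ligand from metabotropic glutamate receptor 2 (Homo sapiens), read by scintillation counting, with a stated time of 60 min; on this read-out higher numbers stand for weaker inhibition and lower numbers for stronger inhibition:
- compound 1, `Cc1cc(Oc2ccc(-c3ccn4c(CC5CC5)nnc4c3Cl)cc2F)ccn1`: compound 1 gives 63.1 nM
- compound 2, `Cc1cc(Oc2ccc(-c3ccn4c(CC5CC5)nnc4c3C(F)(F)F)cc2F)ccn1`: compound 2 gives 7.08 nM
- compound 3, `Clc1cc(-c2ccn3c(CC4CC4)nnc3c2Cl)ccc1NC1CCOCC1`: compound 3 gives 38.9 nM

Compounds 1 and 2 share a core and differ in one place, described as trifluoromethyl in place of chloro on an aromatic carbon. That single change gave an 8.9-fold lower number from compound 1 to compound 2 (0.95 log units; beyond the scatter). Compound 3 carries a different core from compound 1; the difference between the two cores is not broken down here. In this assay compound 3 sits nearest to compound 1, the two numbers lying within the usual scatter, and furthest from compound 2, which gives the lowest number of the three.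

Compound 4, `FC(F)(F)c1c(-c2ccc(NC3CCOCC3)c(Cl)c2)ccn2c(CC3CC3)nnc12`, has not yet been measured. It is related to compound 3 by trifluoromethyl in place of chloro on an aromatic carbon. The place of this change, read from the two structures, is the same word for word as the place of the change from compound 1 to compound 2, so it is the same change made on a second core.

On that ground compound 4 is expected to give a step of about a 7.8-fold lower number from compound 3 to compound 4 (0.89 log units; beyond the scatter) in this assay, of roughly the size seen as an 8.9-fold lower number from compound 1 to compound 2 (0.95 log units; beyond the scatter). Within the data shown here, only one such pair supports this, and the second core may not respond alike; the expectation is held loosely. For compound 4 the estimate in this assay is 5 nM, expected to fall between 1.5 nM and 16 nM.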

Compound 4, inhibition constant: 5.01 nM
Compound 4: middle estimate off by 1.0-fold (0.00 log units), on the low side, within the range that was stated.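

In this assay, putting trifluoromethyl in place of chloro on the aromatic carbon of the second core gave a 7.8-fold lower number from compound 3 to compound 4 (0.89 log units; beyond the scatter) and so repeated the step seen on the first core. Across the two cores, the size of the step did not depend measurably on which core carried it, and the gap between the two steps gives no ground for treating them as different: the same change on two cores in this assay, an 8.9-fold lower number (0.95 log units; beyond the scatter) from compound 1 to compound 2 and a 7.8-fold lower number (0.89 log units; beyond the scatter) from compound 3 to compound 4, 1.1-fold (0.06 log units) apart, within the scatter of two such steps. Among these compounds, this shows that the change carried over between these two cores in this one read-out, but it rests on only two matched pairs and does not show that the step would hold on any further core, nor does it explain why the number falls.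

The compounds shown leave open how other groups on that aromatic carbon, such as a nitrile, a methyl or a bromine atom, would compare with chloro and trifluoromethyl. They also leave open whether the step would keep its size if the group on the triazole-free side of the series were changed, for example if a carboxylic acid or a longer chain stood in place of the groups present here.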